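The source may hold more compounds than are shown below. What is called first, only, known or untested is meant among the compounds shown, and "the series" means these compounds.

The shared core of compound 1 `Oc1ccc(-c2cc(-c3ccccc3O)cc(-c3cccc(O)c3)n2)cc1` carries three hydroxyphenyl groups, and in a functional assay on HCT-15 cells (Homo sapiens) for cytotoxicity, read by CCK-8 assay, with a stated time of 4 days (a lower number here means a stronger inhibitor, a higher number a weaker inhibitor), compound 1 gives 4850 nM. Among the two plain numbers in this assay, compound 1 stands lowest, yet compound 2 `Oc1ccc(-c2cc(-c3ccc(O)cc3)nc(-c3ccc(O)cc3)c2)cc1`, which gives 5120 nM, sits within the usual scatter of it, so the two cannot be told apart. Compound 3 `Oc1cccc(-c2cc(-c3cccc(O)c3)nc(-c3ccccc3O)c2)c1` reaches only a limit in this assay, reported as > 50000 nM. Compound 4 `Oc1cccc(-c2cc(-c3ccccc3O)cc(-c3cccc(O)c3)n2)c1` differs from compound 1 in one place: 3-hydroxyphenyl in place of 4-hydroxyphenyl on an aromatic carbon. Going by the values given here, no step between two measured compounds matches this change, so its size has to be guessed. Compound 3 carries the same three hydroxyphenyl groups as compound 4, joined differently, and in this assay compound 3 gives > 50000 nM, a limit. That is the only hint, and it points toward weaker inhibition. The step of a 3.1-fold higher number from compound 1 to compound 4 (0.49 log units; beyond the scatter) is therefore expected to raise the number, by more than the scatter. For compound 4 the estimated value in this assay is 15000 nM, with a likely range from 5000 nM to 50000 nM.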

Compound 4, half-maximal inhibitory concentration: 5150 nM
Beside the measured number, compound 4's estimate is 2.9-fold (0.46 log units) above it; low and high end bracket the measured number.
By their numbers in this assay, from the lowest: compounds 1, 2 and 4 (each within the scatter of the next). At a limit, above all of these: compound 3.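

Exchanging 4-hydroxyphenyl for 3-hydroxyphenyl on the aromatic carbon next to the ring nitrogen gives a 1.1-fold higher number from compound 1 to compound 4 (0.03 log units; within the scatter) in this assay. Going by these compounds alone, this is the first direct reading at this position, as no earlier pair differed in one place, and it shows that the two hydroxyphenyl groups cannot be told apart here. The finding rests on this single pair and extends to no other position on the shared core.

Within the data shown here, the one limit among the compounds gives no size for any step: the limit of > 50000 nM in this assay, at which 1 of the 4 values shown sits. As far as these compounds go, how the number would respond to a 2-hydroxyphenyl group at this place, to a methoxyphenyl or aminophenyl group, or to a carboxylic acid in place of the hydroxyl stays open.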